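The compounds below may be only part of what the source reports. "The series", "measured", "known", "first", "only" and "open" are said of these compounds alone.

Within the data shown here, in a functional assay on BGC-823 cells (Homo sapiens) for antiproliferative activity, read by MTT assay, with a stated time of 48 h (a lower number here means a stronger inhibitor, a higher number a weaker inhibitor), three compounds have numbers so far. Compound 1 `Brc1ccccc1CSc1nnc(-c2cnccn2)o1` gives 17600 nM, compound 2 `c1ccc(CSc2nnc(-c3cnccn3)s2)cc1` gives 21200 nM, and compound 3 `Clc1ccccc1CSc1nnc(-c2cnccn2)n1-c1ccccc1` gives 34700 nM. Compound 3 stands level with the other two, since its number lies within the usual scatter of both compound 2 and compound 1, and these data do not rank the three. Among the measured compounds shown here, no two of them differ in only one place, so no measured step is available as a guide.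

The next compound to be tested is compound 4 `Clc1ccc(CSc2nnc(-c3cnccn3)n2-c2ccccc2)cc1`, which has the same atoms as compound 3, joined differently: 4-chlorophenyl in place of 2-chlorophenyl on a saturated chain carbon bound to a sulfur. In words, 4-chlorophenyl stands in place of 2-chlorophenyl on a saturated chain carbon bound to a sulfur. For the measured compounds named here, nothing measured so far shows what this exchange does in this assay, so no step beyond the scatter is expected, in either direction. That expectation rests on compound 3 and its value of 34700 nM, with the other two compounds lying within the scatter of it. The expected change is small, a 1.2-fold lower number from compound 3 to compound 4 (0.06 log units; within the scatter). For compound 4 the estimated value is 30000 nM, with an expected range from 14000 nM to 60000 nM.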

Compound 4, half-maximal inhibitory concentration: 27700 nM
The estimate for compound 4 lay 1.1-fold (0.03 log units) above the measured number, within the range that was stated.
By their numbers in this assay, from the lowest: compounds 1, 2, 4 and 3 (each within the scatter of the next).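

Among these compounds, this is the first measured step that changes one place only: in this assay, 4-chlorophenyl in place of 2-chlorophenyl on a saturated chain carbon bound to a sulfur gives a 1.3-fold lower number from compound 3 to compound 4 (0.10 log units; within the scatter). With the same atoms joined differently and the rest of the structure held constant, this pair shows that the exchange between these two chlorophenyl groups does not separate the compounds in this assay, a finding that compounds 1, 2 and 3 could not give, since none of them differed from another in only one place. No independent measurement bears on what lies behind this result.

On these data alone, the pair speaks only to these two chlorophenyl groups at this one position, so it remains open whether an unsubstituted phenyl, a methoxy group, an amine or a carboxylic acid on that phenyl, or a longer chain in place of the chlorobenzyl group, would give a step beyond the scatter. As far as these compounds go, compounds 1 and 2 each differ from compounds 3 and 4 in more than one place, so steps to them cannot be read, and what the shared core contributes also remains open.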